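From hydroxy to 3-aminopropyl on the chain of compound 1

A few compounds are considered here, and "the series" means these few. Any claim that something is new, unique, unknown or untested is made for them only; others in the source may bear on it.

In an ADME assay on HeLa cells (Homo sapiens) for cytotoxicity, read by MTT assay (a lower number here means a stronger inhibitor, a higher number a weaker inhibitor), compound 1 (`OCCNc1ccnc2cc(Cl)ccc12`) gives > 100000 nM as a limit, not a number. Compound 2 (`Cc1cn([C@H]2C[C@H](NC(=O)C(=O)NCCCCCNc3ccnc4cc(Cl)ccc34)[C@@H](CO)O2)c(=O)[nH]c1=O`) gives > 100000 nM as a limit too. For the measured compounds named here, compound 3 (`Cc1cn([C@H]2C[C@H](NC(=O)C(=O)NCCCCCNc3ccnc4cc(Cl)ccc34)[C@@H](CO[Si](c3ccccc3)(c3ccccc3)C(C)(C)C)O2)c(=O)[nH]c1=O`) gives 28700 nM as the only true number so far. Compound 4 (`NCCCCCNc1ccnc2cc(Cl)ccc12`) carries 3-aminopropyl in place of hydroxy on a saturated chain carbon, two bonds along the chain from a nitrogen on an aromatic ring. Going by the values given here, no measured step sizes this change, and the one number available as a guide is compound 3 at 28700 nM for now. A moderate move toward stronger inhibition is expected, estimated as an at least 3.3-fold lower number from compound 1 to compound 4 (0.52 log units; beyond the scatter) in this series. Compound 4 is expected at 30000 nM (estimated range 8000 nM to 100000 nM).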

Compound 4, half-maximal inhibitory concentration: 56600 nM
Compound 4: middle estimate off by 1.9-fold (0.28 log units), on the low side, and the stated range covers the measured number.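

In this assay the change from hydroxy to 3-aminopropyl on the saturated chain carbon gives an at least 1.7-fold lower number from compound 1 to compound 4 (0.24 log units; that floor lies within the scatter). The size of this step remains a floor, because compound 1 sits at a limit and not at a number: the limit of > 100000 nM in this assay, at which 2 of the 4 values shown sit. This place on the chain can therefore bring the series to a true number, though the floor alone does not establish a change beyond the scatter.

Open, from the compounds shown here alone, is whether the amine or the added chain length carries the step. A 3-hydroxypropyl or an aminomethyl group at the same place would separate the two.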